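Fluorine on a Sulfamoyl-Bearing Ring: Expected Cytotoxicity

The compounds below may be only part of what the source reports. "The series", "measured", "known", "first", "only" and "open" are said of these compounds alone.

Compound 1, `CC1(C)C[C@H](O)C[C@](C)(CNc2nc3ccccc3s2)C1`, and compound 2, `CC1(C)C[C@H](O)C[C@](C)(CNc2nc3ccc(F)cc3s2)C1`, share one core and differ by a single change, (fluoro in place of hydrogen on an aromatic carbon). In an ADME assay on MDCK cells (Canis lupus familiaris) for cytotoxicity, read by MTT assay, with a stated time of 3 days (on this read-out higher numbers stand for lower toxicity in this test and lower numbers for higher toxicity in this test), compound 1 gives 36800 nM, and compound 2 gives 16200 nM; this is a 2.3-fold lower number from compound 1 to compound 2 (0.36 log units; beyond the scatter). Compound 3, `CC1(C)C[C@H](O)C[C@](C)(CNc2cccc(S(N)(=O)=O)c2)C1`, carries a different core, and the difference between the two cores is not broken down here. In this assay compound 3 reaches only a limit of the test, > 100000 nM, as recorded in the limit of > 100000 nM in this assay, at which 1 of the 3 values shown sits. Compound 4, `CC1(C)C[C@H](O)C[C@](C)(CNc2cc(F)cc(S(N)(=O)=O)c2)C1`, is not yet measured; it differs from compound 3 by fluoro in place of hydrogen on an aromatic carbon. This is the same kind of change as between compound 1 and compound 2, but here it sits meta to a sulfamoyl group on a ring of carbon only, rather than on a fused system of two rings. Because compound 3 already stands at the limit of > 100000 nM in this assay, at which 1 of the 3 values shown sits, and the earlier step was a 2.3-fold lower number from compound 1 to compound 2 (0.36 log units; beyond the scatter), compound 4 is expected to show an at least 1.1-fold lower number from compound 3 to compound 4 (0.04 log units; that floor lies within the scatter). The estimate for compound 4 is 90000 nM.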

Compound 4, half-maximal cytotoxic concentration: 55000 nM
Compound 4: middle estimate off by 1.6-fold (0.21 log units), on the high side; the measured number falls inside the stated range.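

With fluoro in place of hydrogen on an aromatic carbon, this assay shows an at least 1.8-fold lower number from compound 3 to compound 4 (0.25 log units; that floor lies within the scatter), a step that points the same way as the one on the core of compound 1. This gives two cores with a lower number after the change, but two cores cannot show that the change behaves alike on every core in this series. Whether the size of the step carries over cannot be read, since the comparison stays unsettled: the same change on two cores in this assay, a 2.3-fold lower number (0.36 log units; beyond the scatter) from compound 1 to compound 2 and an at least 1.8-fold lower number (0.25 log units; that floor lies within the scatter) from compound 3 to compound 4; the limit leaves it open whether they differ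

The compounds shown leave open whether a chloro or a methyl group in the same place would lower the number as well. They also leave open what fluoro would do if a carboxylic acid stood in place of the sulfamoyl group.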